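A few compounds are considered here, and "the series" means these few. Any claim that something is new, unique, unknown or untested is made for them only; others in the source may bear on it.

Compounds measured in a functional assay on K562 cells (Homo sapiens) for cytotoxicity, read by MTT assay, with a stated time of 48 h; on this read-out higher numbers stand for weaker inhibition and lower numbers for stronger inhibition:
compound 1, `COc1cc([C@@H]2C[C@]2(CO)C(=O)Nc2ccccc2Cl)cc(OC)c1OC`: 16900 nM
compound 2, `CCOC(=O)[C@]1(C(=O)Nc2ccccc2Cl)C[C@H]1c1cc(OC)c(OC)c(OC)c1`: 20700 nM

Compound 1 stands lowest of the two numbers, its nearest neighbour being compound 2 with a 1.2-fold higher number from compound 1 to compound 2 (0.09 log units; within the scatter), a change of ethoxycarbonyl in place of hydroxymethyl on a saturated ring carbon. Compound 3, `COc1cc([C@@H]2C[C@@]2(CO)C(=O)Nc2ccccc2Cl)cc(OC)c1OC`, has not yet been measured in this assay. How it differs from compound 1: the two compounds have the same atoms and bonds and differ only in configuration as drawn: 1 of 2 stereo elements differ; a stereocentre at a saturated ring carbon is drawn S in compound 1 and R in compound 3. Within the data shown here, no measured step bears on a change of configuration; the only measured step, a 1.2-fold higher number from compound 1 to compound 2 (0.09 log units; within the scatter), exchanges a group and carries no information about the stereocentre. Among the measured compounds shown here, the measured steps therefore support no direction for the step to compound 3, and a swing beyond the scatter either way cannot be ruled out. Compound 3 is estimated at 22000 nM (range 8000 nM to 65000 nM), which corresponds to an expected step of a 1.3-fold higher number from compound 1 to compound 3 (0.11 log units; within the scatter).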

Compound 3, half-maximal inhibitory concentration: 18400 nM
Beside the measured number, compound 3's estimate is 1.2-fold (0.08 log units) above it; the measured number falls inside the stated range.
By their numbers in this assay, from the lowest: compounds 1, 3 and 2 (each within the scatter of the next).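

Among these compounds, the only earlier step at this saturated ring carbon exchanged one group for another, and it said nothing about the stereocentre. In this assay the change from S to R gives a 1.1-fold higher number from compound 1 to compound 3 (0.04 log units; within the scatter) and so stays within the scatter, which means that with hydroxymethyl on this carbon, the configuration drawn here shows no measurable effect on the number. The comparison speaks to this stereocentre alone, because nothing else separates the pair: the fact that compounds 1 and 3 differ only in the configuration as drawn.

The compounds shown do not tell whether the same holds with ethoxycarbonyl on this carbon, or what the second stereo element contributes. They also leave open whether a carboxylic acid or an amine at this position would move the number beyond the scatter in either configuration.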